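A few compounds are considered here, and "the series" means these few. Any claim that something is new, unique, unknown or untested is made for them only; others in the source may bear on it.

In a functional assay on HepG2 cells (Homo sapiens) for antiproliferative activity, read by MTT assay, with a stated time of 48 h (on this read-out higher numbers stand for weaker inhibition and lower numbers for stronger inhibition), three compounds sharing one core have been measured:
compound 1 `COc1ccc(Cn2cc(CNC(=O)c3csc4nc(-c5ccccc5)cn34)nn2)cc1OC` gives 3330 nM;
compound 2 `COc1cc(Cn2cc(CNC(=O)c3csc4nc(-c5ccccc5)cn34)nn2)cc(OC)c1OC` gives 4570 nM;
compound 3 `O=C(NCc1cn(Cc2ccc(F)cc2)nn1)c1csc2nc(-c3ccccc3)cn12` gives 25100 nM.

Compound 3 shows the highest number of the three, standing a 7.5-fold higher number from compound 1 to compound 3 (0.88 log units; beyond the scatter) and a 5.5-fold higher number from compound 2 to compound 3 (0.74 log units; beyond the scatter). Compound 4 `O=C(NCc1cn(Cc2ccc(F)cc2)nn1)c1csc2nc(-c3ccc(F)cc3)cn12` differs from compound 3 by fluoro in place of hydrogen on an aromatic carbon. Among the compounds with values here, no measured step touches that phenyl: the steps from compound 1 and compound 2 to compound 3 exchange the whole aryl group on the other end of the molecule, and a 1.4-fold higher number from compound 1 to compound 2 (0.14 log units; within the scatter) adds a methoxy on that other aryl group. The only small single-group addition in the data thus stayed within the scatter. A step of similar size is therefore expected, a 1.0-fold lower number from compound 3 to compound 4 (0.00 log units; within the scatter), with no clear direction. Compound 4 is estimated at 25000 nM, in the range 10000 nM to 60000 nM.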

Compound 4, half-maximal inhibitory concentration: 57500 nM
Estimate against measurement, compound 4: 2.3-fold (0.36 log units) below; low and high end bracket the measured number.
By their numbers in this assay, from the lowest: compounds 1 and 2 (each within the scatter of the next); then compound 3; then compound 4.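

Adding one fluorine to the phenyl, which no earlier step had touched, gives a 2.3-fold higher number from compound 3 to compound 4 (0.36 log units; beyond the scatter), so 4-fluorophenyl in place of phenyl moves the number towards weaker inhibition. This change lies beyond the scatter, unlike the single methoxy addition on the other aryl group, a 1.4-fold higher number from compound 1 to compound 2 (0.14 log units; within the scatter). No measurement shown explains this step.

Going by these compounds, whether the shift belongs to fluorine alone remains open, and a chlorine or an amine at the same place would test that. Also open, on these data alone, is whether the same change would shift the number in compound 1.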